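This account rests on a few compounds, and the source may have more. Where it says the series, first, only, none or still open, it means among the compounds named here.

Measured compounds in a functional assay on A549 cells (Homo sapiens) for antiproliferative activity, read by MTT assay, with a stated time of 72 h; on this read-out lower numbers stand for stronger inhibition and higher numbers for weaker inhibition:
- Compound 1 `Cc1ccc(N2C(=O)COc3ccc(-c4cnc5ccccc5c4)cc32)cc1` reports only a limit, not a number, in this assay: > 40000 nM.
- Compound 2 `COc1ccc(N2C(=O)COc3ccc(-c4cnc(OC)c(NS(=O)(=O)c5ccc(F)cc5)c4)cc32)cc1` gives 1350 nM.
- Compound 3 `COc1ncc(-c2ccc3c(c2)N(c2ccc(F)cc2)C(=O)CO3)cc1NS(=O)(=O)c1ccc(F)cc1` gives 6500 nM.

Compound 1 stands at the limit of > 40000 nM in this assay, at which 1 of the 3 values shown sits; its value is a limit and nothing more can be read from it. Compounds 2 and 3, which carry numbers, differ from compound 1 in several places, so they set no direct reference for it. For the measured compounds named here, the one measured step, a 4.8-fold higher number from compound 2 to compound 3 (0.68 log units; beyond the scatter), concerns the aryl group on the amide nitrogen, but with fluoro in place of methoxy, and the two compounds it joins are far from compound 1 in the rest of the structure.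

Compound 4 `O=C1COc2ccc(-c3cnc4ccccc4c3)cc2N1c1ccc(Cl)cc1` differs from compound 1 by chloro in place of methyl on an aromatic carbon. Going by the values given here, no measured step covers chloro in place of methyl at that position, so there is nothing that would move the number away from where compound 1 sits. The expectation for compound 4 in this assay is therefore a step of no size beyond the scatter, a number no higher from compound 1 to compound 4 (the limit leaves the size open), with a good chance that only a limit is reported again.

Compound 4 is estimated at 40000 nM, with a range from 12000 nM to 150000 nM.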

Compound 4, half-maximal inhibitory concentration: > 40000 nM
Compound 4 ended at the assay's limit; the forecaster's own chance of this, stated with the estimate: 75%; the middle value sits exactly at the limit.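

Compound 1 and compound 4 each report only a limit, so the pair gives no readable new step: the limit of > 40000 nM in this assay, at which 2 of the 4 values shown sit.

Going by these compounds, still open in this assay is whether chloro in place of methyl changes the read-out at all, and which of the several structural differences separates compound 2 and compound 3 from these two limits.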